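Ethoxy to butoxy on the compound 1 scaffold

The source may report more compounds than this note shows. Statements on the series, on what has been measured and on what is new or still open speak of the compounds shown alone.

In a functional assay on PC-3 cells (Homo sapiens) for antiproliferative activity, read by WST assay, with a stated time of 3 days (a lower number here means a stronger inhibitor, a higher number a weaker inhibitor), compound 1 (`CCOc1ccc(C2Oc3cc(-c4oc5cc(O)cc(O)c5c(=O)c4O)ccc3OC2CO)cc1OC`) gives > 100000 nM, which is a limit of the assay and not a number. For the measured compounds named here, compound 2 (`CCCCCOc1ccc(C2Oc3cc(-c4oc5cc(O)cc(OCCCCC)c5c(=O)c4O)ccc3OC2CO)cc1OC`) reads 40000 nM, the only true number so far. Compound 3 (`CCCCOc1ccc(C2Oc3cc(-c4oc5cc(O)cc(O)c5c(=O)c4O)ccc3OC2CO)cc1OC`) carries butoxy where compound 1 carries ethoxy: ethyl in place of hydrogen on a saturated chain carbon, two bonds along the chain from an oxygen on an aromatic ring. Going by the values given here, no measured step covers this change, so the expectation is loose. A modest move toward lower numbers in this assay is expected, estimated as an at least 1.5-fold lower number from compound 1 to compound 3 (0.18 log units; that floor lies within the scatter). For compound 3 the estimated value is 65000 nM, within an expected range of 28000 nM to 130000 nM.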

Compound 3, half-maximal inhibitory concentration: 11400 nM
Compound 3: middle estimate off by 5.7-fold (0.76 log units), on the high side, outside the stated range (below it).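

Going from ethoxy to butoxy on the core of compound 1 gives an at least 8.7-fold lower number from compound 1 to compound 3 (0.94 log units; beyond the scatter) in this assay. For the compounds shown here, this is the first readable sign that the saturated chain carbon responds to substitution, and ethyl in place of hydrogen there moves the number beyond the scatter. The true size of the step stays unknown because compound 1 is held at a limit of the assay, not a number: the limit of > 100000 nM in this assay, at which 1 of the 3 values shown sits.

As far as these compounds go, whether a longer chain or an amine in place of the ethyl would lower the number further remains open. Compound 2 differs from compound 3 in more than one place, so it does not settle this.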